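The source may report more compounds than this note shows. Statements on the series, on what has been measured and on what is new or still open speak of the compounds shown alone.

In a functional assay on HT-29 cells (Homo sapiens) for antiproliferative activity, read by sulforhodamine B assay, with a stated time of 48 h (on this read-out higher numbers stand for weaker inhibition and lower numbers for stronger inhibition), three compounds with a shared core have been measured. Compound 1 `Cc1ccc(NS(=O)(=O)c2ccc(N3CCNC3=O)cc2)cc1` gives 480 nM, compound 2 `CCc1cccc(NS(=O)(=O)c2ccc(N3CCNC3=O)cc2)c1` gives 110 nM, and compound 3 `O=C1NCCN1c1ccc(S(=O)(=O)Nc2cccc(Br)c2)cc1` gives 77 nM. Compound 3 sits at the low end of this small set, an end it shares with compound 2. The step of a 1.4-fold lower number from compound 2 to compound 3 (0.15 log units; within the scatter) lies within the scatter, so bromo in place of ethyl shows no measurable change here.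

The next compound, compound 4 `Cc1ccc(C)c(NS(=O)(=O)c2ccc(N3CCNC3=O)cc2)c1`, keeps the core and carries 2,5-dimethylphenyl in place of 3-bromophenyl on a sulfonamide nitrogen. The most relevant evidence comes from the two modest steps that start at the 4-methylphenyl of compound 1, a 4.4-fold lower number from compound 1 to compound 2 (0.64 log units; beyond the scatter) and a 6.2-fold lower number from compound 1 to compound 3 (0.79 log units; beyond the scatter). Both lie beyond the scatter and show that the group at this place can shift the number. Among the measured compounds shown here, compound 1, the only measured compound with a methyl group there, has the highest value, 480 nM. For the measured compounds named here, no measured compound carries a 2,5-dimethylphenyl group, so this comparison is only a loose guide. A modest move towards a higher number is therefore expected in this assay, and the expected step is a 2.2-fold higher number from compound 3 to compound 4 (0.34 log units; beyond the scatter). Compound 4 is estimated at 170 nM, with an expected range of 60 nM to 450 nM.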

Compound 4, half-maximal inhibitory concentration: 46 nM
Beside the measured number, compound 4's estimate is 3.7-fold (0.57 log units) above it, outside the stated range (below it).
By their numbers in this assay, from the lowest: compounds 4, 3 and 2 (each within the scatter of the next, the first and the last beyond it); then compound 1.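

In this assay, the 2,5-dimethylphenyl group on the sulfonamide nitrogen places compound 4 at the low end of the set, and a 1.7-fold lower number from compound 3 to compound 4 (0.22 log units; within the scatter) leaves it indistinguishable from compound 3 despite the exchange of a bromine-bearing ring for one carrying only carbon. Until now, the sole methyl-bearing ring at this place belonged to compound 1, the highest value, but a 10-fold lower number from compound 1 to compound 4 (1.02 log units; beyond the scatter) is a large step and shows that methyl groups on this ring do not in themselves go with a high number, while a 2.4-fold lower number from compound 2 to compound 4 (0.38 log units; beyond the scatter) also separates compound 4 from the ethyl-bearing compound 2, even though compound 2 and compound 3 lie within the scatter of each other. Nothing available here accounts for these differences among the rings.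

The compounds shown leave open what each of the two methyl groups of compound 4 contributes on its own, since this ring differs from the ring of compound 1 in more than one respect. They also leave open whether a ring carrying a methoxy group, an amine or a carboxylic acid at this place would keep the number this low.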